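Selenium-linked bis-acyl isoureas: methyl to benzyl step

This account rests on a few compounds, and the source may have more. Where it says the series, first, only, none or still open, it means among the compounds named here.

Measured so far in a functional assay on K562 cells (Homo sapiens) for cytotoxicity, read by MTT assay, with a stated time of 72 h; a higher number here means a weaker inhibitor of growth, a lower number a stronger inhibitor of growth:
- compound 1, `CS/C(=N\C(=O)c1csc([N+](=O)[O-])c1)NC(=O)c1csc([N+](=O)[O-])c1`: 56900 nM
- compound 2, `C[Se]/C(=N\C(=O)c1ccno1)NC(=O)c1ccno1`: 870 nM
- compound 3, `C[Se]/C(=N\C(=O)c1cnc2ccccc2c1)NC(=O)c1cnc2ccccc2c1`: 3800 nM

Compound 3 sits second highest of the three numbers. Its nearest neighbour is compound 2, whose number is lower by a margin beyond the scatter; compound 1 lies furthest away, with a much higher number, also beyond the scatter. The three compounds differ from one another in more than one place, so none of these gaps can be tied to a single structural change.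

Compound 4, `O=C(/N=C(/NC(=O)c1cnc2ccccc2c1)[Se]Cc1ccccc1)c1cnc2ccccc2c1`, is not yet measured. It keeps the core of compound 3 and differs only at the chalcogen substituent: phenyl in place of hydrogen on a saturated chain carbon bound to a selenium atom. In the shorter reading this is methyl to benzyl on the selenium.

Within the data shown here, no measured pair in this set isolates such a change, so there is no directly comparable step to lean on. With nothing in the numbers for compounds 1, 2 and 3 to point either way, the expected step is small, likely within the scatter, with a modest margin allowed for either direction. On that basis the step from compound 3 to compound 4 is expected to be a 1.3-fold lower number from compound 3 to compound 4 (0.10 log units; within the scatter). Compound 4 is expected to give about 3000 nM in this assay, with a range from 900 nM to 10000 nM.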

Compound 4, concentration for 50% growth inhibition: 29300 nM
The estimate for compound 4 lay 9.8-fold (0.99 log units) below the measured number; the whole stated range lies below it.
By their numbers in this assay, from the lowest: compound 2; then compound 3; then compounds 4 and 1 (each within the scatter of the next).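

In this assay, among these compounds, the only step that changes one place is a 7.7-fold higher number from compound 3 to compound 4 (0.89 log units; beyond the scatter), and it lies beyond the scatter in the direction of weaker growth inhibition. Among the compounds shown here, this shows that the saturated chain carbon bound to a selenium atom is not a silent place on this core: methyl to benzyl, with phenyl in place of hydrogen, changes the read-out clearly, something the earlier compounds could not show as they differ from one another in more than one place. Nothing available bears on the reason for this step, so it stands as an observation without an explanation.

A single step cannot tell whether the phenyl ring itself matters or whether any addition at this carbon would move the number the same way; an ethyl group, a longer chain, or a chain ending in an amine or a carboxylic acid would help separate these readings. From the compounds shown here alone, it also remains open whether methyl to benzyl carries over to other acyl groups on the shared core, such as those of compound 2.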